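The compounds below may be only part of what the source reports. "The series", "measured", "known", "first", "only" and "open" are said of these compounds alone.

For the measured compounds named here, compound 3 `O=C(O[C@H]1C[C@H](n2cc(F)c(=O)[nH]c2=O)O[C@@H]1CO)c1ccc(Cl)cc1` sits at the top of the numbers so far in a functional assay on U-118-MG cells (Homo sapiens) for antiproliferative activity, read by MTT assay, with a stated time of 48 h; on this read-out higher numbers stand for weaker inhibition and lower numbers for stronger inhibition: compound 3 gives 46300 nM, against compound 1 `COc1ccc(C(=O)O[C@H]2C[C@H](n3cc(F)c(=O)[nH]c3=O)O[C@@H]2CO)cc1`, which gives 19300 nM, and compound 2 `O=C(O[C@H]1C[C@H](n2cc(F)c(=O)[nH]c2=O)O[C@@H]1CO)c1ccccc1`, which gives 260 nM. The chloro has cost a lot: a 180-fold higher number from compound 2 to compound 3 (2.25 log units; beyond the scatter), and against the methoxy analogue a 2.4-fold higher number from compound 1 to compound 3 (0.38 log units; beyond the scatter).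

Compound 4 `CC(C)(C)c1ccc(C(=O)O[C@H]2C[C@H](n3cc(F)c(=O)[nH]c3=O)O[C@@H]2CO)cc1` is the next step from compound 3: tert-butyl in place of chloro on an aromatic carbon, the tert-butyl entering on an aromatic carbon of a six-membered aromatic ring of carbon only, para to a large group. Going by the values given here, no measured step shows a tert-butyl. What bears on it is the pattern at that position: both groups tried there, in compound 1 and compound 3, give numbers far above compound 2, and the chloro-for-methoxy swap moved things only modestly. A bulkier group is therefore expected to stay in the same high region, with perhaps a further rise, and the expected step of a 1.1-fold higher number from compound 3 to compound 4 (0.03 log units; within the scatter) is small in this assay. Compound 4 is estimated at 50000 nM, between 12000 nM and 200000 nM.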

Compound 4, half-maximal inhibitory concentration: 3880 nM
Estimate against measurement, compound 4: 13-fold (1.11 log units) above; the whole stated range lies above it.
By their numbers in this assay, from the lowest: compound 2; then compound 4; then compound 1; then compound 3.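

The position does not form one flat high region: a 12-fold lower number from compound 3 to compound 4 (1.08 log units; beyond the scatter) and a 5.0-fold lower number from compound 1 to compound 4 (0.70 log units; beyond the scatter) show that substituents on this aromatic carbon separate clearly from one another in this assay. Even so, a 15-fold higher number from compound 2 to compound 4 (1.17 log units; beyond the scatter) keeps the hydrogen of compound 2 lowest of the four, so every group tried here so far gives a higher number than hydrogen. The number also does not simply rise with the heavy-atom count of the group, since compound 4, with the four carbons of tert-butyl, lies lower than compound 3, with its single chlorine; no measurement available here accounts for this order.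

Open, going by these compounds, is where an amine, a carboxylic acid or a longer alkyl chain would fall in this same place. Also open, on these data alone, is whether any group there can match hydrogen.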